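The source may report more compounds than this note shows. Statements on the series, on what has been measured and on what is new or still open speak of the compounds shown alone.

Working notes on the acetyl-bearing compounds in an ADME assay on KB cells (Homo sapiens) for cytotoxicity, read by MTT assay, with a stated time of 72 h; on this read-out lower numbers stand for stronger inhibition and higher numbers for weaker inhibition. Compound 1 `COc1ccc(C2=C(c3cc(OC)c(OC)c(OC)c3)C(=O)C(OC(C)=O)C2)cc1OC(C)C` gives > 100 ug/mL, which is a limit of the assay. Compound 2 `COc1ccc(C2=C(c3cc(OC)c(OC)c(OC)c3)C(=O)C(OC(C)=O)C2)cc1F` gives 33 ug/mL, and compound 3 `COc1ccc(C2=C(c3cc(OC)c(OC)c(OC)c3)C(=O)C(O)C2)cc1F` gives 4.5 ug/mL. Compound 2 therefore holds the higher of the two actual numbers, with a 7.3-fold lower number from compound 2 to compound 3 (0.87 log units; beyond the scatter) on replacing acetyl with hydrogen. That step lies at a different place in the structure and has little bearing here.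

Compound 4 `COc1ccc(C2=C(c3cc(OC)c(OC)c(OC)c3)C(=O)C(OC(C)=O)C2)cc1Cl` keeps the acetyl and differs from compound 2 at one place: chloro in place of fluoro on an aromatic carbon. The nearest evidence is the change at that same aromatic carbon, where fluoro in place of isopropoxy gives an at least 3.0-fold lower number from compound 1 to compound 2 (0.48 log units; beyond the scatter). This size is only a bound, given (the limit of > 100 ug/mL in this assay, at which 1 of the 3 values shown sits). Exchanging one halogen for another is a much smaller change, so no step beyond the scatter is expected in this assay. The estimated step is a 1.1-fold higher number from compound 2 to compound 4 (0.03 log units; within the scatter). The expected value for compound 4 is 35 ug/mL, with an estimated range of 13 ug/mL to 90 ug/mL.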

Compound 4, half-maximal inhibitory concentration: 64 ug/mL
Compound 4: the middle estimate sits 1.8-fold (0.26 log units) below what was measured, within the range that was stated.
By their numbers in this assay, from the lowest: compound 3; then compounds 2 and 4 (each within the scatter of the next). At a limit, above all of these: compound 1.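

In this assay, exchanging one halogen for the other at this carbon, ortho to a methoxy group, gives a 1.9-fold higher number from compound 2 to compound 4 (0.29 log units; within the scatter), so chloro and fluoro are not told apart at this position. Chloro in place of isopropoxy gives an at least 1.5-fold lower number from compound 1 to compound 4 (0.19 log units; that floor lies within the scatter), whereas fluoro in place of isopropoxy gave an at least 3.0-fold lower number from compound 1 to compound 2 (0.48 log units; beyond the scatter), so only the fluoro step is shown to exceed the scatter. Compound 1 stands at a limit, so both steps from it are bounds and not sizes: the limit of > 100 ug/mL in this assay, at which 1 of the 4 values shown sits.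

The compounds shown leave open how an amine or a carboxylic acid at this carbon would read in this assay. Also open, as far as these compounds go, is whether hydrogen in place of acetyl on the chloro compound would repeat a 7.3-fold lower number from compound 2 to compound 3 (0.87 log units; beyond the scatter).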